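The source may report more compounds than this note shows. Statements on the series, on what has been measured and on what is new or still open speak of the compounds shown alone.

Within the data shown here, in an in vitro functional assay on HEK ts201 cells for antagonist activity at Neuronal acetylcholine receptor; alpha4/beta2 (Homo sapiens), read by fluorescence and calcium flux (a higher number here means a weaker inhibitor, a lower number a stronger inhibitor), compound 2 `CC1CC(=O)N(c2ccccc2C(=O)OCC2CCCN(CCCCCCc3ccccc3)C2)C1=O` gives 29500 nM, the higher of the two numbers measured so far. The nearest measured neighbour is compound 1 `CC1CC(=O)N(c2ccccc2C(=O)OCC2CCCN(CCCCOc3ccccc3)C2)C1=O`, which in this assay gives 1700 nM; the two are separated by a 17-fold higher number from compound 1 to compound 2 (1.24 log units; beyond the scatter), a large step. Compound 3 `CC1CC(=O)N(c2ccccc2C(=O)OCC2CCCN(CCCCCOc3ccccc3)C2)C1=O` is not yet measured. It differs from compound 2 by phenoxy in place of benzyl on a saturated chain carbon, five bonds along the chain from an amine nitrogen in a ring, so an oxygen returns to the chain in place of a carbon, one bond further from the ring nitrogen than in compound 1. Among the measured compounds shown here, the only measured step that bears on this change is a 17-fold higher number from compound 1 to compound 2 (1.24 log units; beyond the scatter), which ran the opposite way and made the inhibitor much weaker. Reversing it is therefore expected to lower the number, though the longer chain leaves the size uncertain, so the expected step is an 8.4-fold lower number from compound 2 to compound 3 (0.93 log units; beyond the scatter). Compound 3 is estimated at 3500 nM, within a range of 1000 nM to 12000 nM.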

Compound 3, half-maximal inhibitory concentration: 17000 nM
Compound 3: the middle estimate sits 4.9-fold (0.69 log units) below what was measured, outside the stated range (above it).
By their numbers in this assay, from the lowest: compound 1; then compounds 3 and 2 (each within the scatter of the next).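

In this assay, phenoxy in place of benzyl on a saturated chain carbon, five bonds along the chain from an amine nitrogen in a ring, gives a 1.7-fold lower number from compound 2 to compound 3 (0.24 log units; within the scatter), so at this chain length the oxygen makes no readable difference. With the oxygen kept, phenoxymethyl in place of phenoxy, four bonds along the chain from that nitrogen, gives a 10-fold higher number from compound 1 to compound 3 (1.00 log units; beyond the scatter), so the weakening seen earlier with compound 2 does not depend on losing the oxygen. Nothing here explains why this longer chain gives a higher number.

On these data alone, it remains open whether a shorter chain than that of compound 1, still ending in phenoxy, would lower the number further. Also open, as far as these compounds go, is how an amine nitrogen in place of the chain oxygen would behave.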